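Swapping the halogenated aryl on the piperazine of compound 1

The source may hold more compounds than are shown below. What is called first, only, known or untested is meant among the compounds shown, and "the series" means these compounds.

Within the data shown here, compound 1, with the structure `CCCn1c(=O)[nH]c2nc(-c3ccc(S(=O)(=O)N4CCN(c5cccc(Cl)c5)CC4)cc3)[nH]c2c1=O`, is the only compound here with a number rather than a limit: in an assay on CHO cells for displacement of a labelled ligand from adenosine receptor A3 (Homo sapiens), read by scintillation counting, with a stated time of 45 min, in the presence of a further agent that is not named here (on this read-out lower numbers stand for stronger inhibition and higher numbers for weaker inhibition), compound 1 gives 53.5 nM. Its companion compound 2, with the structure `CCCn1c(=O)c2[nH]c(-c3ccc(S(=O)(=O)N4CCN(c5ccc(Cl)cc5)CC4)cc3)nc2n(CC)c1=O`, differs from compound 1 in more than one place, so the two are not compared directly. In this assay compound 2 reaches only a limit of the assay, > 1000 nM, and no number is known for it; this is the one case of the limit of > 1000 nM in this assay, at which 1 of the 2 values shown sits, among the two values. Compound 1 therefore stands alone as the measured reference.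

The next compound, compound 3, has the structure `CCCn1c(=O)[nH]c2nc(-c3ccc(S(=O)(=O)N4CCN(c5ccc(I)cc5)CC4)cc3)[nH]c2c1=O`. It keeps the whole of compound 1 apart from one change: 4-iodophenyl in place of 3-chlorophenyl on an amine nitrogen in a ring. One halogen-bearing phenyl is exchanged for another on the same ring nitrogen, with no change in donor or acceptor count. Among the measured compounds shown here, no measured step of this kind is available, so the expectation rests on the closeness of the two groups alone; the step from compound 1 to compound 3 in this assay is expected to be a 1.1-fold higher number from compound 1 to compound 3 (0.05 log units; within the scatter), a shift not beyond the usual scatter in either direction. On that basis compound 3 is estimated to give about 60 nM in this assay, most plausibly between 20 nM and 200 nM.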

Compound 3, inhibition constant: > 1000 nM
Compound 3 was reported as a limit (the forecaster's own chance of this, stated with the estimate: 10%); middle value at least 16-fold (1.22 log units) away from the limit.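

In this assay, this one exchange on the ring nitrogen of the piperazine has a large effect, with an at least 18-fold higher number from compound 1 to compound 3 (1.27 log units; beyond the scatter). The value for compound 3 is a limit of the assay and not a number, and it is the second such value in this short series: the limit of > 1000 nM in this assay, at which 2 of the 3 values shown sit. The change therefore shows that this position does not accept every halogen-bearing phenyl alike: 3-chlorophenyl and 4-iodophenyl match in heavy atoms, hydrogen-bond donors, hydrogen-bond acceptors and net charge, yet they are clearly not interchangeable here, so those counts alone do not tell how a group will behave at this position.

The step changes both the halogen and where it sits on the phenyl ring, so compound 1 and compound 3 cannot show whether the iodine, its place on the ring, or the two together account for the loss. A 3-iodophenyl group or an unsubstituted phenyl on the core of compound 1 would bear on that question, and a 3-methoxyphenyl group would show whether this position needs a halogen at all.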